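Working notes on compound 2 and compound 3

The source may report more compounds than this note shows. Statements on the series, on what has been measured and on what is new or still open speak of the compounds shown alone.

Compound 1 `COc1ccc(NC(=O)CSC(=S)N[C@H]2CCOC2=O)cc1`: > 128000 nM
Compound 2 `CC(=O)c1ccc(NC(=O)CSC(=S)N[C@H]2CCOC2=O)cc1`: > 128000 nM
Compound 3 `O=C(CSC(=S)N[C@H]1CCOC1=O)Nc1ccc(C(=O)/C=C/c2ccc([N+](=O)[O-])cc2)cc1`: to be measured

In a functional assay on MCF7 cells (Homo sapiens) for cytotoxicity, read by MTT assay, with a stated time of 72 h (on this read-out higher numbers stand for weaker inhibition and lower numbers for stronger inhibition), compound 1 gives > 128000 nM, which is a limit of the assay. In this assay compound 2 gives > 128000 nM, also a limit. The step that the two limits leave unreadable from compound 1 to compound 2 therefore has no readable size; both values sit at the limit of > 128000 nM in this assay, at which 2 of the 2 values shown sit. Compound 3 differs from compound 2 by 2-(4-nitrophenyl)ethenyl in place of methyl on a carbonyl carbon. Within the data shown here, no measured step gives a readable size that bears on this change, so the expected step of an at least 4.2-fold lower number from compound 2 to compound 3 (0.63 log units; beyond the scatter) rests on the structural change alone and carries wide uncertainty. Compound 3 is expected near 30000 nM, within 3000 nM to 128000 nM.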

Compound 3, half-maximal inhibitory concentration: 2670 nM
Estimate against measurement, compound 3: 11-fold (1.05 log units) above; the whole stated range lies above it.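

Placing 2-(4-nitrophenyl)ethenyl in place of methyl on a carbonyl carbon gives, in this assay, an at least 47-fold lower number from compound 2 to compound 3 (1.68 log units; beyond the scatter). This is the only readable step in the series, as the step from compound 1 to compound 2 cannot be read and both compounds sit at a limit: the limit of > 128000 nM in this assay, at which 2 of the 3 values shown sit.

The compounds shown do not separate the contribution of the ethenyl link from that of the nitro-bearing ring. Going by these compounds, how an amine in place of the nitro group, or an unsubstituted phenyl, would read in this assay remains open.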